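Methyl to methoxy on the aryl of the shared core

The source may report more compounds than this note shows. Statements on the series, on what has been measured and on what is new or still open speak of the compounds shown alone.

Two compounds have a number in an assay on HepG2 cells for agonist activity at nuclear receptor subfamily 1 group I member 3 (Homo sapiens), read by a luciferase reporter, with a stated time of 23 h (on this read-out higher numbers stand for an effect only at larger amounts of compound and lower numbers for an effect already at smaller amounts), so far. Compound 1 `Cc1ccc(-c2nc3sccn3c2/C=N/OCc2ccc(Cl)c(Cl)c2)cc1` gives 490 nM and stands lowest of the two. Within the data shown here, compound 2 `COc1ccc(CO/N=C/c2c(-c3ccc4ccccc4c3)nc3occn23)cc1` gives 4400 nM in this assay, a number that lies beyond the scatter from compound 1; the two structures differ in several places, so the pair shows only that compound 2 needs a larger amount.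

Compound 3 `COc1ccc(-c2nc3sccn3c2/C=N/OCc2ccc(Cl)c(Cl)c2)cc1` has not been measured in this assay. It differs from compound 1 in one place, (methoxy in place of methyl on an aromatic carbon), with the rest of the structure kept. Among the measured compounds shown here, no measured pair isolates this change, so there is no step to lean on.

The expectation is that the change from compound 1 to compound 3 moves the number little, with a step of a 1.2-fold higher number from compound 1 to compound 3 (0.09 log units; within the scatter) that is expected to stay within the scatter, direction uncertain. Compound 3 is therefore estimated at 600 nM in this assay, in a range from 200 nM to 2000 nM.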

Compound 3, half-maximal effective concentration: 490 nM
For compound 3 the middle estimate is 1.2-fold (0.09 log units) above the measured one; measured number inside the range.
By their numbers in this assay, from the lowest: compounds 1 and 3 (each within the scatter of the next); then compound 2.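

Among these compounds, this is the first one-place step: in this assay, the exchange of 4-methylphenyl for 4-methoxyphenyl on the shared core gives no change at the digits printed from compound 1 to compound 3 (within the scatter) and so separates this change from the several differences in the earlier pair. At this aromatic carbon, para to a large group, one more heavy atom and one hydrogen-bond acceptor leave the number where it stood, at least with the rest of compound 1 kept. No measurement at hand accounts for this result.

Going by these compounds, whether the position keeps its number with an amine, a carboxylic acid or a longer chain such as butoxy in place of methoxy remains open. Also open, on these data alone, is whether the same exchange reads alike when other parts of the structure differ from compound 1.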